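Swapping a Chloro for an Amino on a Purine Core

The compounds below may be only part of what the source reports. "The series", "measured", "known", "first", "only" and "open" are said of these compounds alone.

Measured so far:
compound 1 `ClCc1ccccc1Cn1cnc2c(Cl)nc(Cl)nc21` — 510 nM
compound 2 `Nc1nc(Cl)c2ncn(Cc3ccc(CCl)cc3)c2n1` — 5500 nM
compound 3 `ClCc1ccccc1Cn1cnc2ncnc(Cl)c21` — 4160 nM

All three compounds were tested in a functional assay on OVCAR-3 cells (Homo sapiens) for cytotoxicity, read by sulforhodamine B assay, with a stated time of 48 h; on this read-out lower numbers stand for stronger inhibition of growth and higher numbers for weaker inhibition of growth. Compound 1 gives the lowest number of the three and therefore the strongest growth inhibition; compound 3 gives 4160 nM, and compound 2 lies furthest away with 5500 nM. Both of these differences from compound 1 lie outside the usual scatter.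

The next compound to consider is compound 4 `Nc1nc(Cl)c2ncn(Cc3ccccc3CCl)c2n1`, which has not yet been measured in this assay. It is derived from compound 1 by a single change: amino in place of chloro on an aromatic carbon. Compound 4 thus shares its amino-and-chloro substitution pattern on the core with compound 2, while keeping the chloromethyl-substituted benzyl group of compound 1.

Within the data shown here, no direct step for this exchange has been measured, so the expectation rests on the surrounding numbers. Compound 2, which carries the amino group, and compound 3, which carries no group at that carbon, both give clearly weaker inhibition than compound 1. The step from compound 1 to compound 4 is therefore expected to be an increase in the number, a 7.8-fold higher number from compound 1 to compound 4 (0.89 log units; beyond the scatter), beyond the scatter. In this assay compound 4 is estimated at 4000 nM, within a range from 1200 nM to 13000 nM.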

Compound 4, concentration for total growth inhibition: 20000 nM
Beside the measured number, compound 4's estimate is 5.0-fold (0.70 log units) below it; measured number above the stated range.
By their numbers in this assay, from the lowest: compound 1; then compounds 3 and 2 (each within the scatter of the next); then compound 4.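

In this assay, putting amino in place of chloro on the aromatic carbon between two ring nitrogen atoms gives a 39-fold higher number from compound 1 to compound 4 (1.59 log units; beyond the scatter), a large step. Among these compounds, the earlier compounds offered no pair that differed in one place, so this is the first direct reading of this position, and it shows that amino does not stand in for chloro here when the rest of compound 1 is held fixed. The data shown offer no explanation for why the number rises so far with this exchange.

The compounds shown leave open whether this large step belongs to amino itself or would follow any replacement of chloro at this carbon, a question that a methoxy group, a fluoro group or a methylamino group on the same carbon could help to answer. They also leave open whether the same exchange would give a step of similar size in a compound that carries a different group in place of the chloromethyl group.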